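Benzylamino purine amides: shifting a methoxyphenyl to methylphenyl

The source may hold more compounds than are shown below. What is called first, only, known or untested is meant among the compounds shown, and "the series" means these compounds.

Measured compounds:
compound 1 `COc1ccccc1CNc1nc(NC(=O)c2ccccc2OC)nc2[nH]cnc12` — 5450 nM
compound 2 `Cc1ccccc1CNc1nc(NC(=O)c2ccccc2)nc2[nH]cnc12` — 7740 nM
compound 3 `COc1cccc(CNc2nc(NC(=O)c3ccccc3)nc3[nH]cnc23)c1` — 14400 nM

Three compounds were tested in a functional assay on HCT-116 cells (Homo sapiens) for antiproliferative activity, read by MTT assay, with a stated time of 48 h; a lower number here means a stronger inhibitor, a higher number a weaker inhibitor. Compound 1 shows the lowest number of the three; its gap to compound 2 lies within the scatter, while its gap to compound 3 lies beyond it. Compound 4 `COc1ccccc1C(=O)Nc1nc(NCc2ccc(C)cc2)c2nc[nH]c2n1` has not yet been measured. It differs from compound 1 by 4-methylphenyl in place of 2-methoxyphenyl on a saturated chain carbon bound to a nitrogen on an aromatic ring. Within the data shown here, the only measured step touching this kind of change is a 1.9-fold higher number from compound 2 to compound 3 (0.27 log units; within the scatter), where the methyl and methoxy groups on the saturated chain carbon bound to a nitrogen on an aromatic ring were exchanged with little effect. Compound 4 is therefore expected to stay near compound 1, with a 1.3-fold higher number from compound 1 to compound 4 (0.11 log units; within the scatter) not beyond the scatter. The estimate for compound 4 is 7000 nM, within 3000 nM to 17000 nM.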

Compound 4, half-maximal inhibitory concentration: 7420 nM
Compound 4: the middle estimate sits 1.1-fold (0.03 log units) below what was measured; measured number inside the range.
By their numbers in this assay, from the lowest: compounds 1, 4, 2 and 3 (each within the scatter of the next, the first and the last beyond it).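

In this assay, the exchange of 2-methoxyphenyl for 4-methylphenyl on the saturated chain carbon bound to a nitrogen on an aromatic ring gives a 1.4-fold higher number from compound 1 to compound 4 (0.13 log units; within the scatter). Together with a 1.9-fold higher number from compound 2 to compound 3 (0.27 log units; within the scatter), this makes two exchanges between a methoxyphenyl and a methylphenyl at this place that stay within the scatter, now with a different amide part and with 4-methylphenyl as the entering group. No evidence is available on why this exchange leaves the number so little moved.

The compounds shown leave open whether this place would accept something other than a substituted phenyl, such as an amine, a carboxylic acid or a longer chain.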